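Trimming the ester from compound 3: what compound 4 may show

This account rests on a few compounds, and the source may have more. Where it says the series, first, only, none or still open, it means among the compounds named here.

Measured compounds:
compound 1, `CC(=O)c1c(C)nc2c(OCc3ccccc3)cccn12`: in a functional assay on the whole organism with Rattus norvegicus as the target, with a stated time of 4 h, at a dose of 40 mg/kg by the intraperitoneal route (on this read-out lower numbers stand for less inhibition and higher numbers for more inhibition at the one dose given (going by the name of the read-out)), compound 1 gives 57%
compound 2, `Cc1nc2c(OCc3ccccc3)cccn2c1Cl`: in this assay compound 2 gives 93%
compound 3, `Cc1nc2c(OCc3ccccc3)cccn2c1COC(=O)C(C)(C)C`: in this assay compound 3 gives 48%

Compound 3 stands lowest of the three numbers. Its nearest neighbour is compound 1, and the gap between them, a number 9 percentage points lower from compound 1 to compound 3 (within the scatter), lies within the scatter, so these two cannot be ordered. Its furthest neighbour is compound 2, and the gap a number 45 percentage points lower from compound 2 to compound 3 (beyond the scatter) is large and beyond the scatter.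

Compound 4, `Cc1nc2c(OCc3ccccc3)cccn2c1C`, is reached from compound 3 by a single change: hydrogen in place of ((tert-butyl)carbonyl)oxy on a saturated chain carbon bound to an aromatic carbon. Among the compounds with values here, no measured step removes exactly this group; the two steps that touch the same carbon of the shared core are a number 45 percentage points lower from compound 2 to compound 3 (beyond the scatter), where a small substituent was exchanged for the larger one, and a number 9 percentage points lower from compound 1 to compound 3 (within the scatter), where the exchange was between two larger groups. The one small substituent measured, in compound 2, carries the highest number, while the two larger ones sit lower and close together. Compound 4 is therefore expected to move upward from compound 3, estimated as a number 20 percentage points higher from compound 3 to compound 4 (beyond the scatter), though with wide uncertainty since a single pair supports this. The estimate for compound 4 is 68%, expected to fall between 45% and 90%.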

Compound 4, a percentage reported as inhibition, in the whole organism at one dose (the size of the read-out at that dose, not a potency): 99%
Compound 4: the middle estimate sits 31 percentage points below what was measured, outside the stated range (above it).
By their numbers in this assay, from the lowest: compounds 3 and 1 (each within the scatter of the next); then compounds 2 and 4 (each within the scatter of the next).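

Removing ((tert-butyl)carbonyl)oxy from the saturated chain carbon, which turns (((tert-butyl)carbonyl)oxy)methyl into methyl, gives in this assay a number 51 percentage points higher from compound 3 to compound 4 (beyond the scatter), so the low number of the ester compound does not carry over to the plain methyl compound. The high number seen with chloro is also not peculiar to that group: there is a number 6 percentage points higher from compound 2 to compound 4 (within the scatter), so these two compounds cannot be ordered, while methyl in place of acetyl gives a number 42 percentage points higher from compound 1 to compound 4 (beyond the scatter), leaving methyl and chloro together above acetyl and the ester-bearing group. Nothing offered here accounts for why these numbers move as they do.

The compounds shown leave open whether a hydroxymethyl group, an aminomethyl group or a longer chain such as ethyl on this aromatic carbon would stay with methyl and chloro or fall with acetyl and the ester-bearing group. They also leave open whether methyl and chloro would separate at a lower dose or another time, since the read-out here gives the size of the effect at a single dose and not a potency.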